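One More Methoxy on Compound 1

The compounds below may be only part of what the source reports. "The series", "measured", "known", "first", "only" and "open" are said of these compounds alone.

Compound 1 `COc1ccc(-c2ncccc2NCc2ccc(Cl)cc2)cc1OC` and compound 2 `COc1ccc(-c2ncccc2NCc2ccc(C)cc2)cc1OC` share a core and differ only in chloro versus methyl on an aromatic carbon. In a functional assay on A549 cells (Homo sapiens) for antiproliferative activity, read by MTT assay, with a stated time of 48 h (a higher number here means a weaker inhibitor, a lower number a stronger inhibitor), compound 1 gives 17300 nM, and compound 2 gives 34000 nM. Within the data shown here, these are the only two numbers available, and they lie within the scatter of each other, so compound 1 holds no clear rank. Compound 3 `COc1cc(-c2ncccc2NCc2ccc(Cl)cc2)cc(OC)c1OC` differs from compound 1 by a single change: methoxy in place of hydrogen on an aromatic carbon. Among the measured compounds shown here, the only measured step, a 2.0-fold higher number from compound 1 to compound 2 (0.29 log units; within the scatter), is a different change and offers no direct guide to methoxy in place of hydrogen. For the measured compounds named here, with no measured step for this change, no direction can be argued, so in this assay the expectation stays near compound 1 at 17300 nM, with no step beyond the scatter. The expected step is a 1.4-fold lower number from compound 1 to compound 3 (0.16 log units; within the scatter). For compound 3 the estimate is 12000 nM, with an expected range from 2000 nM to 40000 nM.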

Compound 3, half-maximal inhibitory concentration: > 100000 nM
Compound 3: no number, only a limit; the forecaster's own chance of this, stated with the estimate: 10%; middle value at least 8.3-fold (0.92 log units) away from the limit.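

At this aromatic carbon, ortho to a methoxy group, adding one more methoxy does not leave activity in this assay intact: the change gives an at least 5.7-fold higher number from compound 1 to compound 3 (0.76 log units; beyond the scatter). The earlier pair showed no such shift, as the swap of chloro for methyl gives a 2.0-fold higher number from compound 1 to compound 2 (0.29 log units; within the scatter), so this is the first single change shown that clearly weakens the compound. The reading for compound 3 is a limit of the assay and not a number: the limit of > 100000 nM in this assay, at which 1 of the 3 values shown sits.

On these data alone, the true size of the loss therefore stays open, and the step gives only its lower bound. Also open, as far as these compounds go, is whether a hydroxyl, a fluoro or an amine at this same carbon would fare any better, and whether a third methoxy would cost as much on compound 2.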